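Swapping the Fluorophenyl for Methoxyphenyl on a Weak Core

This account rests on a few compounds, and the source may have more. Where it says the series, first, only, none or still open, it means among the compounds named here.

Going by the values given here, compound 1, `COc1cc(-c2nnc3n2NC(c2ccco2)C(C(=O)c2ccccc2F)S3)cc(OC)c1OC`, carries the only actual number in this small set: in a functional assay on A549 cells (Homo sapiens) for cytotoxicity, read by MTT assay, with a stated time of 48 h (on this read-out higher numbers stand for weaker inhibition and lower numbers for stronger inhibition), compound 1 gives 78700 nM. Compound 2, `COc1cc(-c2nnc3n2NC(c2ccco2)C(C(=O)c2ccc(C)cc2)S3)cc(OC)c1OC`, reaches only a limit of this assay, > 100000 nM. Compound 3, `COc1ccc(C(=O)C2Sc3nnc(-c4cc(OC)c(OC)c(OC)c4)n3NC2c2ccco2)cc1`, likewise stops at a limit of this assay, > 100000 nM. Both steps away from compound 1 are therefore floors: an at least 1.2-fold higher number from compound 1 to compound 2 (0.10 log units; that floor lies within the scatter) and an at least 1.2-fold higher number from compound 1 to compound 3 (0.10 log units; that floor lies within the scatter), set by the limit of > 100000 nM in this assay, at which 2 of the 3 values shown sit. Compound 4, `COc1cccc(C(=O)C2Sc3nnc(-c4cc(OC)c(OC)c(OC)c4)n3NC2c2ccco2)c1`, differs from compound 1 by 3-methoxyphenyl in place of 2-fluorophenyl on a carbonyl carbon. Because the two comparable swaps gave an at least 1.2-fold higher number from compound 1 to compound 2 (0.10 log units; that floor lies within the scatter) and an at least 1.2-fold higher number from compound 1 to compound 3 (0.10 log units; that floor lies within the scatter), no gain is expected. The expected step is a 1.4-fold higher number from compound 1 to compound 4 (0.15 log units; within the scatter). The estimate for compound 4 is 110000 nM, from 50000 nM to 250000 nM, and a limit rather than a number is quite possible.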

Compound 4, half-maximal inhibitory concentration: > 100000 nM
Compound 4: only a limit was reported; the forecaster's own chance of this, stated with the estimate: 60%; the middle value is on the limit's open side.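

With 3-methoxyphenyl in place of 2-fluorophenyl on the carbonyl carbon, this assay shows an at least 1.2-fold higher number from compound 1 to compound 4 (0.10 log units; that floor lies within the scatter). This third replacement at this position also gives no readable gain over compound 1. The steps among compound 2, compound 3 and compound 4 cannot be read, because all three stop at a limit: the limit of > 100000 nM in this assay, at which 3 of the 4 values shown sit.

From the compounds shown here alone, how far compound 1 truly stands from the other three remains open. Also open, going by these compounds, is whether an amine or a carboxylic acid on this phenyl ring would give a lower number in this assay.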